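The source may report more compounds than this note shows. Statements on the series, on what has been measured and on what is new or still open speak of the compounds shown alone.

Measured compounds:
compound 1, `CNc1ncnc2c1c(I)cn2[C@@H]1O[C@H](CO)[C@@H](O)[C@H]1O`, gives only a limit in an ADME assay on BJ cells (Homo sapiens), read by MTT assay, with a stated time of 72 h; on this read-out lower numbers stand for stronger inhibition and higher numbers for weaker inhibition: > 100000 nM.
compound 2, `COc1ncnc2c1c(I)cn2[C@@H]1O[C@H](CO)[C@@H](O)[C@H]1O`, in this assay: 91000 nM.
compound 3, `CNc1ncnc2c1c(-c1ccco1)cn2[C@@H]1O[C@H](CO)[C@@H](O)[C@H]1O`, in this assay: 5040 nM.

The value of compound 1 is not a number but (the limit of > 100000 nM in this assay, at which 1 of the 3 values shown sits). Two structural changes appear among these compounds. One is methoxy in place of methylamino on an aromatic carbon, which gave an at least 1.0-fold lower number from compound 1 to compound 2 (0.04 log units; that floor lies within the scatter). The other is furan-2-yl in place of iodo on an aromatic carbon, which gave an at least 19-fold lower number from compound 1 to compound 3 (1.29 log units; beyond the scatter), and it is also how the core of compound 3 differs from the core of compound 1. Compound 4, `COc1ncnc2c1c(-c1ccco1)cn2[C@@H]1O[C@H](CO)[C@@H](O)[C@H]1O`, is not yet measured. It differs from compound 3 by methoxy in place of methylamino on an aromatic carbon, the same change as from compound 1 to compound 2, at the same place. Because the earlier step was an at least 1.0-fold lower number from compound 1 to compound 2 (0.04 log units; that floor lies within the scatter), a similarly small step is expected here, a 1.2-fold higher number from compound 3 to compound 4 (0.08 log units; within the scatter). Compound 4 is therefore estimated at 6000 nM, most likely between 2500 nM and 15000 nM.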

Compound 4, half-maximal inhibitory concentration: 430 nM
Estimate against measurement, compound 4: 14-fold (1.14 log units) above; the whole stated range lies above it.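

In this assay, methoxy in place of methylamino gave a 12-fold lower number from compound 3 to compound 4 (1.07 log units; beyond the scatter), and this sits beside the same change on the core of compound 1: the same change on two cores in this assay, an at least 1.0-fold lower number (0.04 log units; that floor lies within the scatter) from compound 1 to compound 2 and a 12-fold lower number (1.07 log units; beyond the scatter) from compound 3 to compound 4; the limit leaves it open whether they differ
Furan-2-yl in place of iodo gave a 210-fold lower number from compound 2 to compound 4 (2.33 log units; beyond the scatter), and both of its steps point to a lower number: the same change on two cores in this assay, an at least 19-fold lower number (1.29 log units; beyond the scatter) from compound 1 to compound 3 and a 210-fold lower number (2.33 log units; beyond the scatter) from compound 2 to compound 4; the limit leaves it open whether they differ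
The value of compound 1 is a limit and not a number, so these pairs show no answer to whether either step keeps its size from one core to another: the limit of > 100000 nM in this assay, at which 1 of the 4 values shown sits.

The compounds shown leave open how ethoxy or an unsubstituted amine would behave in place of methoxy on the core of compound 4. They also leave open whether a longer chain there would follow the same trend.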